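Trimming the fused ring group of compound 3

The source may hold more compounds than are shown below. What is called first, only, known or untested is meant among the compounds shown, and "the series" means these compounds.

Measured in a physicochemical assay for solubility, in phosphate buffer, at pH 7.4 (on this read-out higher numbers stand for higher solubility and lower numbers for lower solubility), so far:
Compound 1 `CC(=O)N[C@@H]1CCC[C@H](C(=O)Nc2cc(-c3cnn4c3CCCC4)c(F)cn2)C1` gives > 1000000 nM as a limit of the assay and not a number
Compound 2 `CC(=O)N[C@@H]1CCC[C@H](C(=O)Nc2cc(-c3cnn4c3CCCC4)c(Cl)cn2)C1` gives 310000 nM as its measured value
Compound 3 `CC(=O)N[C@@H]1CCC[C@H](C(=O)Nc2cc(-c3cnn4ccccc34)c(Cl)cn2)C1` gives 45000 nM as its measured value

Compound 3 holds the lower of the two exact numbers, and compound 2 holds the higher one. Compound 4 `CC(=O)N[C@@H]1CCC[C@H](C(=O)Nc2cc(-c3cnc(C)n3C)c(Cl)cn2)C1` has not been measured yet. For the measured compounds named here, its one difference from compound 3 is a group of 7 heavy atoms (5 carbon, 2 nitrogen; one five-membered aromatic ring with 2 hetero atoms) in place of a group of 9 heavy atoms (7 carbon, 2 nitrogen; one five-membered aromatic ring with 2 hetero atoms, one six-membered aromatic ring with 1 hetero atom), on an aromatic carbon and the entering group is 1,2-dimethyl-1H-imidazol-5-yl, ortho to a chloro group.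

The chloro group stays in place in compound 3 and compound 4, which leaves an at least 3.2-fold lower number from compound 1 to compound 2 (0.50 log units; beyond the scatter) with no direct bearing on this change. The closer guide is a 6.9-fold lower number from compound 2 to compound 3 (0.84 log units; beyond the scatter) and it swaps the group on this same aromatic carbon. Neither compound 4 nor compound 2 carries the six-membered aromatic ring of compound 3, and compound 2 stands at 310000 nM in this assay which points to an upward move as the likelier direction. The step expected is a 5.6-fold higher number from compound 3 to compound 4 (0.74 log units; beyond the scatter) on the strength of that single comparison. The expected value of compound 4 is 250000 nM within an estimated range from 70000 nM to 900000 nM on this reasoning.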

Compound 4, solubility: > 1000000 nM
Compound 4: only a limit was reported (the forecaster's own chance of this, stated with the estimate: 10%); at least 4.0-fold (0.60 log units) between middle value and limit.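

In this assay compound 4 gives > 1000000 nM, which is a limit of the assay and not a number. Placing 1,2-dimethyl-1H-imidazol-5-yl on this aromatic carbon, ortho to a chloro group, gives an at least 22-fold higher number from compound 3 to compound 4 (1.34 log units; beyond the scatter) and also an at least 3.2-fold higher number from compound 2 to compound 4 (0.50 log units; beyond the scatter), so this single five-membered aromatic ring reads higher than both fused ring groups, whereas the earlier compounds only compared those two fused groups with each other. The true size of both steps cannot be told because the read-out stops at a limit: the limit of > 1000000 nM in this assay, at which 2 of the 4 values shown sit.

The compounds shown do not separate the loss of the fused six-membered ring from the addition of the two methyl groups, since no compound here changes only one of these features. From the compounds shown here alone, it also remains open how a different group on this same carbon, such as a plain phenyl ring, an aminomethyl group or a carboxylic acid, would read out, and a comparison of that kind would need values that fall inside the range of the assay.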